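This account rests on a few compounds, and the source may have more. Where it says the series, first, only, none or still open, it means among the compounds named here.

Working notes on the series, read in a toxicity assay on J774.A1 cells (Mus musculus) for cytotoxicity, read by SYBR Green assay, with a stated time of 1 h; on this read-out lower numbers stand for an effect already at smaller amounts and higher numbers for an effect only at larger amounts of compound. Compound 1 `CN(C)c1ccc2cc(-c3ccccc3)c(N)nc2c1` gives 4900 nM. Compound 2 `CN(C)c1ccc2cc(-c3ccccc3Br)c(N)nc2c1` gives 12000 nM, and compound 3 `CN(C)c1ccc2cc(-c3cccc(Cl)c3)c(N)nc2c1` gives 13000 nM. The last two cannot be told apart, with a 1.1-fold higher number from compound 2 to compound 3 (0.03 log units; within the scatter). Compound 3 thus shares the upper end of the three numbers with compound 2, and only compound 1 lies clearly lower.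

Compound 4 `CN(C)c1ccc2cc(-c3ccc(Cl)c(Cl)c3)c(N)nc2c1` carries one further change relative to compound 3: chloro in place of hydrogen on an aromatic carbon. In words, this is chloro in place of hydrogen on an aromatic carbon, ortho to a chloro group and para to a large group.

Within the data shown here, the closest precedent is the chloro step, a 2.7-fold higher number from compound 1 to compound 3 (0.42 log units; beyond the scatter). The bromo step, a 2.4-fold higher number from compound 1 to compound 2 (0.39 log units; beyond the scatter), is of similar size and runs the same way. Both are modest. Among the measured compounds shown here, neither adds a halogen to a ring that already holds one, so the data contain no direct precedent for this change, and only three measured compounds support the reading. A modest move to a higher number is therefore expected in this assay, though a result within the scatter would not be surprising. The expected step is a 1.7-fold higher number from compound 3 to compound 4 (0.23 log units; within the scatter). Compound 4 is estimated at 22000 nM, with an expected range of 10000 nM to 48000 nM.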

Compound 4, half-maximal effective concentration: 3200 nM
Compound 4: middle estimate off by 6.9-fold (0.84 log units), on the high side; measured number below the stated range.
By their numbers in this assay, from the lowest: compounds 4 and 1 (each within the scatter of the next); then compounds 2 and 3 (each within the scatter of the next).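

Read together, the three chloro and bromo steps in this assay do not share a direction: a 4.1-fold lower number from compound 3 to compound 4 (0.61 log units; beyond the scatter), whereas a 2.7-fold higher number from compound 1 to compound 3 (0.42 log units; beyond the scatter) and a 2.4-fold higher number from compound 1 to compound 2 (0.39 log units; beyond the scatter). Adding a chloro group therefore does not carry a fixed direction across compounds 1 to 4; on the carbon ortho to a chloro group and para to a large group, on a ring already holding a halogen, it gives the opposite sign to the steps from compound 1, and the halogen steps in this small set do not add up. Nothing measured here accounts for this reversal.

As far as these compounds go, it remains open whether the lower number belongs to chloro at this place or to the pair of chloro groups acting together, a question that a ring bearing only the chloro group para to the large group could address. Equally open, from the compounds shown here alone, is whether other groups at this carbon, such as fluoro, methoxy, an amine or a carboxylic acid, would follow compound 4 or the direction of the steps from compound 1.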